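A few compounds are considered here, and "the series" means these few. Any claim that something is new, unique, unknown or untested is made for them only; others in the source may bear on it.

Measured so far in a functional assay on PC-3 cells (Homo sapiens) for cytotoxicity, read by MTT assay, with a stated time of 72 h; a lower number here means a stronger inhibitor, a higher number a weaker inhibitor:
compound 1 `Cc1ccc(S(=O)(=O)c2nc3ccccc3nc2Nc2ccc(Cl)cc2)cc1` gives 9660 nM
compound 2 `Cc1ccc(S(=O)(=O)c2nc3ccccc3nc2Nc2ccc(C(F)(F)F)cc2)cc1` gives 2540 nM
compound 3 `O=S(=O)(c1ccc(Br)cc1)c1nc2ccccc2nc1Nc1ccc(Cl)cc1` gives 7460 nM

Compound 4 `O=S(=O)(c1ccc(Br)cc1)c1nc2ccccc2nc1Nc1ccc(C(F)(F)F)cc1` is not yet measured. It differs from compound 3 by trifluoromethyl in place of chloro on an aromatic carbon. The same change has been made once before in this series, as trifluoromethyl in place of chloro on an aromatic carbon, where it gave a 3.8-fold lower number from compound 1 to compound 2 (0.58 log units; beyond the scatter). The place of the change reads alike in both cases, so it is the same change carried onto a second core. The two cores differ by bromo in place of methyl on an aromatic carbon, a change that gave a 1.3-fold lower number from compound 1 to compound 3 (0.11 log units; within the scatter), a step within the usual scatter. With one prior example of the change, and the core difference having shifted the numbers little, the expectation is for a step of about the same size in this assay: a 3.7-fold lower number from compound 3 to compound 4 (0.57 log units; beyond the scatter) is expected. Compound 4 is therefore estimated at 2000 nM, with a range from 900 nM to 4500 nM.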

Compound 4, half-maximal inhibitory concentration: 4150 nM
Beside the measured number, compound 4's estimate is 2.1-fold (0.32 log units) below it; the measured number falls inside the stated range.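

In this assay, trifluoromethyl in place of chloro on the second core gives a 1.8-fold lower number from compound 3 to compound 4 (0.25 log units; within the scatter), and this does not differ beyond the scatter from the step on the first core: the same change on two cores in this assay, a 3.8-fold lower number (0.58 log units; beyond the scatter) from compound 1 to compound 2 and a 1.8-fold lower number (0.25 log units; within the scatter) from compound 3 to compound 4, 2.1-fold (0.33 log units) apart, within the scatter of two such steps

Bromo in place of methyl, now read with trifluoromethyl in place, gives a 1.6-fold higher number from compound 2 to compound 4 (0.21 log units; within the scatter), and the two readings of this change also agree within the scatter: the same change on two cores in this assay, a 1.3-fold lower number (0.11 log units; within the scatter) from compound 1 to compound 3 and a 1.6-fold higher number (0.21 log units; within the scatter) from compound 2 to compound 4, 2.1-fold (0.33 log units) apart, within the scatter of two such steps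

Going by these compounds alone, the two changes therefore carry between these cores without a detectable dependence on each other, but with only two cores in one assay, this does not show that the steps are equal, and the new trifluoromethyl step does not itself stand clear of the scatter.

The compounds shown leave open how a nitrile, a methoxy group or an amine would read in place of chloro. From the compounds shown here alone, a carboxylic acid in place of bromo or methyl also remains open.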